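Heteroaryl swap on a sulfonamide nitrogen: compound 3 to compound 4

A few compounds are considered here, and "the series" means these few. Any claim that something is new, unique, unknown or untested is made for them only; others in the source may bear on it.

Compound 1 `C=C1CC[C@@H]2[C@](C)(COC(C)=O)[C@H](OC(C)=O)CC[C@@]2(C)[C@H]1CC(Nc1ccc(S(=O)(=O)Nc2nccc(C)n2)cc1)C1=CCOC1=O`: 81200 nM
Compound 2 `C=C1CC[C@@H]2[C@](C)(COC(C)=O)[C@H](OC(C)=O)CC[C@@]2(C)[C@H]1CC(Nc1ccc(S(=O)(=O)Nc2nccs2)cc1)C1=CCOC1=O`: 14300 nM
Compound 3 `C=C1CC[C@@H]2[C@](C)(COC(C)=O)[C@H](OC(C)=O)CC[C@@]2(C)[C@H]1CC(Nc1ccc(S(=O)(=O)Nc2ccc(Cl)nn2)cc1)C1=CCOC1=O`: 12700 nM

In a functional assay on SN12C cells (Homo sapiens) for inhibition, read by sulforhodamine B assay, with a stated time of 48 h (on this read-out higher numbers stand for lower toxicity in this test and lower numbers for higher toxicity in this test), compound 3 gives the lowest of the three numbers, though its separation from compound 2, a 1.1-fold lower number from compound 2 to compound 3 (0.05 log units; within the scatter), lies within the scatter, so the two cannot be ordered. Compound 4 `C=C1CC[C@@H]2[C@](C)(COC(C)=O)[C@H](OC(C)=O)CC[C@@]2(C)[C@H]1CC(Nc1ccc(S(=O)(=O)Nc2ncccn2)cc1)C1=CCOC1=O` differs from compound 3 by pyrimidin-2-yl in place of 6-chloropyridazin-3-yl on a sulfonamide nitrogen. The step that bears on this is a 6.4-fold lower number from compound 1 to compound 3 (0.81 log units; beyond the scatter), where 4-methylpyrimidin-2-yl gave way to 6-chloropyridazin-3-yl; compound 4 reverses that route except for the methyl group, while a 5.7-fold lower number from compound 1 to compound 2 (0.75 log units; beyond the scatter) shows the same size with 1,3-thiazol-2-yl. Compound 4 is therefore expected to show a higher number, an estimated step of a 3.1-fold higher number from compound 3 to compound 4 (0.50 log units; beyond the scatter). Compound 4 is estimated at 40000 nM, with a range from 12000 nM to 110000 nM.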

Compound 4, concentration lethal to 50% of the cells: 5820 nM
For compound 4 the middle estimate is 6.9-fold (0.84 log units) above the measured one; measured number below the stated range.
By their numbers in this assay, from the lowest: compound 4; then compounds 3 and 2 (each within the scatter of the next); then compound 1.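

In this assay the unsubstituted pyrimidin-2-yl on the sulfonamide nitrogen gives the lowest number of the set, with a 2.2-fold lower number from compound 3 to compound 4 (0.34 log units; beyond the scatter) and a 2.5-fold lower number from compound 2 to compound 4 (0.39 log units; beyond the scatter). The largest step, a 14-fold lower number from compound 1 to compound 4 (1.14 log units; beyond the scatter), is hydrogen in place of methyl on an aromatic carbon, so this single methyl separates the two ends of the series, a gap wider than any change of ring shown. Going by these compounds, what a methoxy group or an amine at that carbon would give in this assay stays open. Nothing measured here offers a reason for these steps.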